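From Acid to Methyl Amide: Expected Liver Half-Life

The source may hold more compounds than are shown below. What is called first, only, known or untested is meant among the compounds shown, and "the series" means these compounds.

Of the compounds shown here, three sharing one core have been measured in an in vitro ADME assay on microsomes from liver (Homo sapiens) for metabolic stability; on this read-out higher numbers stand for a longer-lived compound and lower numbers for a shorter-lived compound. Compound 1 `CNS(=O)(=O)c1ccc(-c2cnc(N)c(-c3ccc(OC)nc3)c2)cc1` carries a methylsulfamoyl group, and in this assay compound 1 gives 3.02 h. Compound 2 `COc1ccc(-c2cc(-c3ccc(S(N)(=O)=O)cc3)cnc2N)cn1` has hydrogen in place of methyl on the sulfonamide nitrogen. The value of compound 2 in this assay, > 4.16 h, is a limit and not a number. Compound 3 `COc1ccc(-c2cc(-c3ccc(C(=O)O)cc3)cnc2N)cn1` carries carboxy in place of methylsulfamoyl on an aromatic carbon. The value of compound 3 in this assay, > 4.16 h, is likewise a limit. Compound 3 therefore stands at the top of the numbers shown, together with compound 2 (the limit of > 4.16 h in this assay, at which 2 of the 3 values shown sit). The steps of an at least 1.3-fold higher number from compound 1 to compound 2 (0.13 log units; that floor lies within the scatter) and an at least 1.3-fold higher number from compound 1 to compound 3 (0.13 log units; that floor lies within the scatter) both point upward, though their floors lie within the scatter, while the step that the two limits leave unreadable from compound 2 to compound 3 cannot be read. Compound 4 `CNC(=O)c1ccc(-c2cnc(N)c(-c3ccc(OC)nc3)c2)cc1` arises from compound 3 by methylamino in place of hydroxy on a carbonyl carbon. For the measured compounds named here, no measured step touches a carbonyl carbon, so guidance is thin. Compound 4 is expected to stay long-lived, the step of an at least 1.1-fold lower number from compound 3 to compound 4 (0.07 log units; that floor lies within the scatter) meaning no change beyond the scatter. The estimate for compound 4 in this assay is 3.5 h, within 1.6 h to 6 h.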

Compound 4, half-life: > 4.16 h
Compound 4 gave a limit, no number (the forecaster's own chance of this, stated with the estimate: 45%); middle value at least 1.1-fold (0.07 log units) from the limit.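

Replacing hydroxy with methylamino on the carbonyl carbon turns carboxy into methylcarbamoyl, and the result for compound 4 in this assay is again a limit and not a number: the limit of > 4.16 h in this assay, at which 3 of the 4 values shown sit.

So this position accepts the methyl amide as well as the acid without any loss that can be seen, which the earlier compounds could not show. For the compounds shown here, the one readable step is an at least 1.3-fold higher number from compound 1 to compound 4 (0.13 log units; that floor lies within the scatter), so it gives no firm separation, and the steps to compound 4 from compound 2 and from compound 3 cannot be read.

As far as these compounds go, how far compound 2, compound 3 and compound 4 lie past that limit remains open, so any real difference among them stays hidden. Also open, from the compounds shown here alone, is whether a plain amino group or a longer chain such as ethylamino on the same carbonyl carbon would stay at that limit.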